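This account rests on a few compounds, and the source may have more. Where it says the series, first, only, none or still open, it means among the compounds named here.

Compound 1 `c1ccc(CO/N=C2/C(c3c[nH]c4ccccc34)=Nc3ccccc32)cc1` is the parent of this small set. In a functional assay on MGC-803 cells (Homo sapiens) for cytotoxicity, read by MTT assay, with a stated time of 2 days (a higher number here means a weaker inhibitor, a lower number a stronger inhibitor), compound 1 gives 15400 nM. Compound 3 `Cc1ccc(CO/N=C2/C(c3c[nH]c4ccccc34)=Nc3ccccc32)cc1` carries the same core with a methyl on the benzyl part: in this assay compound 3 gives 22800 nM. The difference between the two, (methyl in place of hydrogen on an aromatic carbon), makes a 1.5-fold higher number from compound 1 to compound 3 (0.17 log units; within the scatter), so the two numbers cannot be told apart.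

Compound 2 `Fc1ccc2c(c1)/C(=N\OCc1ccccc1)C(c1c[nH]c3ccc(F)cc13)=N2` has a different core from compound 1; the difference between the two cores is not broken down here. In this assay compound 2 gives 21300 nM, which sits within the scatter of both compound 1 and compound 3.

Compound 4 `Cc1ccc(CO/N=C2/C(c3c[nH]c4ccc(F)cc34)=Nc3ccc(F)cc32)cc1` stands to compound 2 as compound 3 stands to compound 1: the change is methyl in place of hydrogen on an aromatic carbon, the same change as before, made on the second core. Nothing among these three measured compounds suggests that this methyl matters much. For the measured compounds named here, its only precedent is the step from compound 1 to compound 3, which stayed within the scatter. For compound 4 the step is therefore expected to be a 1.3-fold higher number from compound 2 to compound 4 (0.12 log units; within the scatter), resting on a 1.5-fold higher number from compound 1 to compound 3 (0.17 log units; within the scatter) as the one earlier case. In this assay compound 4 is accordingly estimated at 28000 nM, expected to fall between 14000 nM and 60000 nM.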

Compound 4, half-maximal inhibitory concentration: 20800 nM
The estimate for compound 4 lay 1.3-fold (0.13 log units) above the measured number; the measured number falls inside the stated range.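

Replacing hydrogen with methyl on the benzyl group of the second core gives a 1.0-fold lower number from compound 2 to compound 4 (0.01 log units; within the scatter) in this assay, so benzyl and 4-methylbenzyl cannot be told apart on this core, just as on the core of compound 1. The two cores do not differ in how they take this change: the same change on two cores in this assay, a 1.5-fold higher number (0.17 log units; within the scatter) from compound 1 to compound 3 and a 1.0-fold lower number (0.01 log units; within the scatter) from compound 2 to compound 4, 1.5-fold (0.18 log units) apart, within the scatter of two such steps

This shows that the methyl carries from one core to the other without a step that can be read on either, but it does not show that the methyl has any effect of its own, and two cores are too few to support a rule for the whole series.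

The compounds shown leave open whether another group at this place on the benzyl group, such as a methoxy, a chlorine, an amine or a carboxylic acid, would give a step beyond the scatter. They also leave open what each fluorine on the core of compound 2 contributes alone, and how any of these compounds would behave outside this assay.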